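A Side-Chain Swap on a Shared Core

A few compounds are considered here, and "the series" means these few. Any claim that something is new, unique, unknown or untested is made for them only; others in the source may bear on it.

Among the compounds with values here, compound 1 `CC1=CCC[C@H]2[C@](C)(CC3=CC(=O)C=C(N[C@@H](C(=O)O)C(C)C)C3=O)[C@@H](C)CC[C@]12C` is the only member of this small set that delivers an actual number: in a functional assay on A549 cells (Homo sapiens) for cytotoxicity, read by MTT assay, with a stated time of 72 h (on this read-out higher numbers stand for weaker inhibition and lower numbers for stronger inhibition), compound 1 gives 23800 nM. Compound 2 `CC(C)(C)C1=CC(=O)C=C(NCC(=O)O)C1=O` reaches only a limit of this assay, giving > 200000 nM. Compound 3 `C[C@H](NC1=CC(=O)C=C(C(C)(C)C)C1=O)C(=O)O` likewise stops at a limit, giving > 200000 nM. Within the data shown here, two of the three results therefore sit at the limit of > 200000 nM in this assay, at which 2 of the 3 values shown sit, and the one change that can be traced between measured compounds, a step that the two limits leave unreadable from compound 2 to compound 3, is a step whose size the two limits leave unreadable. Compound 1 thus stands alone as the single anchor for any expectation.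

Compound 4 `CSCC[C@H](NC1=CC(=O)C=C(C[C@]2(C)[C@@H](C)CC[C@]3(C)C(C)=CCC[C@@H]23)C1=O)C(=O)O` differs from compound 1 in a single place: 1-carboxy-3-(methylsulfanyl)propyl in place of 1-carboxy-2-methylpropyl on an amine nitrogen. Among the measured compounds shown here, no measured step touches this part of the molecule, and the unreadable step from compound 2 to compound 3 concerns a different position, so nothing in the set says whether the new side chain should help or hurt. The expectation is therefore a step with no clear direction, a 1.0-fold higher number from compound 1 to compound 4 (0.00 log units; within the scatter), lying within the usual scatter. Compound 4 is accordingly estimated at 24000 nM, with a likely range from 8000 nM to 70000 nM.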

Compound 4, half-maximal inhibitory concentration: 47300 nM
The estimate for compound 4 lay 2.0-fold (0.29 log units) below the measured number, and the stated range covers the measured number.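

Within the data shown here, this is the first step in the set that can be read; the one earlier step joins two limits of this assay, so its size cannot be read. Placing 1-carboxy-3-(methylsulfanyl)propyl in place of 1-carboxy-2-methylpropyl on the amine nitrogen gives a 2.0-fold higher number from compound 1 to compound 4 (0.30 log units; within the scatter), so the two side chains cannot be told apart in this read-out, even though the new chain carries a sulfur atom and the old one does not. Nothing measured here gives a reason for this result.

On these data alone, two side chains on one core are a narrow sample, so it remains open whether an amide or a methyl ester in place of the carboxylic acid, or a 1-carboxy-2-phenylethyl chain on the same amine nitrogen, would separate from compound 1 in this assay. Also open, as far as these compounds go, is whether the 1-carboxy-3-(methylsulfanyl)propyl chain would give a readable number on the core of compound 2, whose own result is only a limit.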